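The source may hold more compounds than are shown below. What is called first, only, known or untested is meant among the compounds shown, and "the series" means these compounds.

Compound 1 `Cc1nn(C(=O)C2CC2)c(N)c1-c1ccc(Cl)c(Cl)c1` was examined in an assay on Sf9 cells for inhibition of inhibitor of nuclear factor kappa-B kinase subunit epsilon (Homo sapiens), read by ADP-Glo, with a stated time of 60 min; on this read-out lower numbers stand for stronger inhibition and higher numbers for weaker inhibition. In this assay compound 1 reaches only a limit, > 100000 nM. Compound 2 `Cc1nn(C(=O)C2CCCCC2)c(N)c1-c1ccc(Cl)c(Cl)c1` likewise stops at a limit in this assay, > 100000 nM. Compound 3 `Cc1nn(C(=O)c2ccccc2)c(N)c1-c1ccc(Cl)c(Cl)c1` also gives no more than a limit in this assay, > 100000 nM. The steps a step that the two limits leave unreadable from compound 1 to compound 2, a step that the two limits leave unreadable from compound 1 to compound 3 and a step that the two limits leave unreadable from compound 2 to compound 3 thus cannot be read, because of the limit of > 100000 nM in this assay, at which 3 of the 3 values shown sit. Compound 4 `Cc1nn(C)c(N)c1-c1ccc(Cl)c(Cl)c1` differs from compound 1 by methyl in place of cyclopropylcarbonyl on an aromatic nitrogen. Among the measured compounds shown here, none of the measured steps covers this change, and all of them are unreadable, so they give no direction and no size for it. Compound 4 is expected to show a number no higher from compound 1 to compound 4 (the limit leaves the size open), a step of no readable size. The estimate for compound 4 in this assay is 100000 nM, within a range from 20000 nM to 500000 nM.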

Compound 4, half-maximal inhibitory concentration: > 100000 nM
Compound 4: a limit, no number; the forecaster's own chance of this, stated with the estimate: 80%; the middle value lies on the limit itself.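

The step from compound 1 to compound 4 cannot be read, as compound 4 also stops at a limit in this assay: the limit of > 100000 nM in this assay, at which 4 of the 4 values shown sit.

The compounds shown leave open whether any group on that aromatic nitrogen would give a readable number in this assay.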